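The compounds below may be only part of what the source reports. "The series", "measured", "known", "first", "only" and "open" are said of these compounds alone.

Measured compounds:
- compound 1, `COc1cc(OC)c(/C=C/S(=O)(=O)Cc2ccc(OC)cc2[N+](=O)[O-])c(OC)c1`: 20000 nM
- compound 2, `COc1ccc(CS(=O)(=O)/C=C/c2cc(OC)c(OC)c(OC)c2)cc1N`: 250 nM
- compound 3, `COC(=O)[C@H](C)Nc1cc(CS(=O)(=O)/C=C/c2c(OC)cc(OC)cc2OC)ccc1OC`: 200 nM

Read-out for all three is a functional assay on K562 cells (Homo sapiens) for cytotoxicity, read by trypan blue exclusion, with a stated time of 96 h; on this read-out higher numbers stand for weaker inhibition and lower numbers for stronger inhibition. Compound 3 gives the lowest of the three numbers. Its nearest neighbour is compound 2, whose value in this assay lies within the scatter of that of compound 3, so no order between the two can be read. Compound 1 stands far off, with a number beyond the scatter above that of compound 3, and is the only one of the three carrying a nitro group on the benzyl ring rather than a nitrogen bearing hydrogen.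

The unmeasured compound 4, `COc1cc(OC)c(/C=C/S(=O)(=O)Cc2ccc(OC)c(NC(C)(C)C(=O)O)c2)c(OC)c1`, keeps every atom of compound 3 and rearranges only the substituent on the ring nitrogen: 1-carboxy-1-methylethyl in place of 1-(methoxycarbonyl)ethyl on a nitrogen on an aromatic ring. The methyl ester becomes a free carboxylic acid and the stereocentre is lost. No pair of measured compounds differing in one place exists, so the size of this kind of step is not shown by the data; compound 2 and compound 3 share only the amino-type nitrogen and the small gap between them.

On that basis the step of a 2.0-fold higher number from compound 3 to compound 4 (0.30 log units; within the scatter) is expected to be small, likely within the scatter, with a slight lean toward a higher number. Compound 4 is estimated at 400 nM, with a range from 120 nM to 1500 nM.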

Compound 4, half-maximal inhibitory concentration: 7.5 nM
Beside the measured number, compound 4's estimate is 53-fold (1.73 log units) above it; the whole stated range lies above it.
By their numbers in this assay, from the lowest: compound 4; then compounds 3 and 2 (each within the scatter of the next); then compound 1.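

Within the data shown here, on a nitrogen on an aromatic ring, the choice of substituent can shift the number by a wide margin: in this assay, 1-carboxy-1-methylethyl in place of 1-(methoxycarbonyl)ethyl gives a large step (a 27-fold lower number from compound 3 to compound 4 (1.43 log units; beyond the scatter)), while the earlier compounds offered no pair differing in one place and so no size for any change here. The two groups hold the same atoms, so this step arises with no change in composition, only in how those atoms are joined, with a free carboxylic acid replacing the methyl ester and the defined stereocentre gone. Nothing measured here bears on the origin of the step.

The step combines two alterations, the ester becoming an acid and a second methyl appearing on the carbon bound to the nitrogen, so the compounds shown leave open which of them carries it. A 1-carboxyethyl group, holding the acid without the second methyl, and a 1-(methoxycarbonyl)-1-methylethyl group, holding the second methyl with the ester, would separate the two, and a longer chain ending in a carboxylic acid would show whether the distance of the acid from the nitrogen matters.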